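Swapping Morpholine for Thiomorpholine on the Thiocarbonyl Carbon

The source may hold more compounds than are shown below. What is called first, only, known or untested is meant among the compounds shown, and "the series" means these compounds.

Of the compounds shown here, three have been measured in a functional assay on HeLa cells (Homo sapiens) for cytotoxicity, read by MTT assay, with a stated time of 72 h, tested at 10 uM; a higher number here means more inhibition of growth at the concentration tested, a lower number less inhibition of growth. Compound 1 `Cc1cccc(/C(N)=N/NC(=S)N2CCN(c3ccccn3)CC2)n1` gives 72.8%, compound 3 `N/C(=N\NC(=S)N1CCCC1)c1ccc(F)cn1` gives 72.7%, and compound 2 `N/C(=N\NC(=S)N1CCOCC1)c1ccccn1` gives 56.3%. Compound 2 stands lowest of the three: its nearest neighbour is compound 3, whose number lies above it by more than the scatter, and compound 1 lies above it by a similar margin. Compound 4 `N/C(=N\NC(=S)N1CCSCC1)c1ccccn1` is the untested member; its difference from compound 2 is thiomorpholin-4-yl in place of morpholin-4-yl on a thiocarbonyl carbon. Going by the values given here, no pair of measured compounds shows this exchange directly, so the expectation rests only on the spread of the three numbers. A small upward step, estimated as a number 6.7 percentage points higher from compound 2 to compound 4 (within the scatter), is expected, not clearly beyond the scatter. Compound 4 is therefore expected to give 63%, with a range from 48% to 78%.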

Compound 4, percent growth inhibition at one concentration: 54.5%
Estimate against measurement, compound 4: 8.5 percentage points above; low and high end bracket the measured number.
By their numbers in this assay, from the lowest: compounds 4 and 2 (each within the scatter of the next); then compounds 3 and 1 (each within the scatter of the next).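

In this assay, thiomorpholin-4-yl in place of morpholin-4-yl on the thiocarbonyl carbon gives a number 1.8 percentage points lower from compound 2 to compound 4 (within the scatter). Going by these compounds alone, this is the first direct test of the exchange, and it shows no change that can be told from the scatter: at this position, this read-out does not separate the ring oxygen from the ring sulfur. No measured evidence bears on this result.

On these data alone, whether the same exchange behaves alike on the cores of compound 1 or compound 3 stays open. Also open, as far as these compounds go, is what a piperidin-1-yl ring or an open-chain dimethylamino group would give on this carbon.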